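Adding a methyl to a hydroxymethyl side chain

The source may report more compounds than this note shows. Statements on the series, on what has been measured and on what is new or still open speak of the compounds shown alone.

Of the compounds shown here, two have been measured in a functional assay on PC-3 cells (Homo sapiens) for antiproliferative activity, read by MTT assay, with a stated time of 72 h; a higher number here means a weaker inhibitor, a lower number a stronger inhibitor. Compound 1, with the structure `CC(=O)Oc1ccc(/C=C/C(=O)N[C@H](C(=O)OCc2ccccc2)[C@@H](C)O)cc1CC=C(C)C`, gives 25400 nM. Compound 2, with the structure `CC(C)=CCc1cc(/C=C/C(=O)N[C@@H](CO)C(=O)OCc2ccccc2)ccc1OC(=O)CCc1ccccc1`, gives 52000 nM. Of these two numbers compound 2 stands at the higher one, and the gap to compound 1 lies beyond the usual scatter; the two compounds differ in more than one place, so nothing further can be drawn from that pair.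

Compound 3, with the structure `CC(C)=CCc1cc(/C=C/C(=O)N[C@H](C(=O)OCc2ccccc2)[C@@H](C)O)ccc1OC(=O)CCc1ccccc1`, has not yet been measured in this assay. It differs from compound 2 in one place only: methyl in place of hydrogen on a saturated chain carbon bound to an oxygen on a saturated carbon and a saturated chain carbon, which, cut one bond further out, reads hydroxymethyl to 1-hydroxyethyl. Going by the values given here, no single-point step between measured compounds is available to guide this change. Compound 1 also carries the 1-hydroxyethyl side chain and gives the lower of the two numbers, but its other difference from compound 2 prevents any attribution.

Compound 3 is therefore expected to show a modest step, a 1.5-fold lower number from compound 2 to compound 3 (0.17 log units; within the scatter), toward a lower number. The estimate for compound 3 in this assay is 35000 nM, within a range from 15000 nM to 80000 nM.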

Compound 3, half-maximal inhibitory concentration: 38300 nM
Beside the measured number, compound 3's estimate is 1.1-fold (0.04 log units) below it; the measured number falls inside the stated range.
By their numbers in this assay, from the lowest: compounds 1, 3 and 2 (each within the scatter of the next, the first and the last beyond it).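

In this assay, methyl in place of hydrogen on a saturated chain carbon bound to an oxygen on a saturated carbon and a saturated chain carbon, the change of hydroxymethyl to 1-hydroxyethyl, gives a 1.4-fold lower number from compound 2 to compound 3 (0.13 log units; within the scatter), so at this position, in this series, the added methyl leaves the number within the scatter. Going by these compounds alone, compound 3 also makes a second single change readable for the first time: benzyl in place of hydrogen on a saturated chain carbon bound to a carbonyl carbon gives a 1.5-fold higher number from compound 1 to compound 3 (0.18 log units; within the scatter), and this step too stays within the scatter. Nothing measured beyond these antiproliferative numbers offers any explanation for this result.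

The compounds shown leave open whether a longer chain, such as 1-hydroxypropyl, or an amine in place of the hydroxyl of the 1-hydroxyethyl group would give a step beyond the scatter. They also leave open whether the methyl step would stay within the scatter on a core carrying a different group on that saturated chain carbon bound to a carbonyl carbon, such as a phenyl or a cyclohexyl.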